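Shortening the alkylamino chain on the shared core

The source may report more compounds than this note shows. Statements on the series, on what has been measured and on what is new or still open speak of the compounds shown alone.

Measured so far in a functional assay (spleen, spleen) for activation, with Mus musculus as the target; a higher number here means that more compound is needed for the effect, a lower number that less compound is needed:
compound 1 `CCCCCNc1nc(N)c2nc(O)n(Cc3ccccc3)c2n1`: 0.1 uM
compound 2 `Nc1ncnc2c1nc(O)n2C1CCCC1`: > 10 uM
compound 3 `Nc1ncnc2c1nc(Cl)n2Cc1ccccc1`: > 10 uM

Among the measured compounds shown here, compound 1 stands alone among the three as the only one with a number in this assay, where compound 1 gives 0.1 uM. The value of compound 2 is a limit of the assay, not a number: > 10 uM. The value of compound 3 is likewise a limit: > 10 uM. Two of the three results therefore sit at the limit of > 10 uM in this assay, at which 2 of the 3 values shown sit, so nothing can be read from them about the size of any single change. For the measured compounds named here, no pair of measured compounds differs in one place only, and no measured step is available.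

Compound 4 `CNc1nc(N)c2nc(O)n(Cc3ccccc3)c2n1` is the next compound to go into this assay. It differs from compound 1 by hydrogen in place of butyl on a saturated chain carbon bound to a nitrogen on an aromatic ring; the same change, cut one bond further out, reads pentylamino to methylamino. Going by the values given here, with no measured step to lean on, the expectation is a loss in this assay beyond the usual scatter, estimated as a 10-fold higher number from compound 1 to compound 4 (1.00 log units; beyond the scatter). Compound 4 is expected to give about 1 uM, within a range from 0.2 uM to 10 uM.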

Compound 4, minimum effective concentration: 1 uM
Compound 4: the middle estimate sits on the measured number at the digits printed; low and high end bracket the measured number.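

In this assay, among the compounds shown here, the change from pentylamino to methylamino on the shared core gives the first readable step: a 10-fold higher number from compound 1 to compound 4 (1.00 log units; beyond the scatter). The butyl part of the chain therefore counts at this place, yet it is not required for a measurable response, as compound 4 still gives a number, 1 uM. Compound 2 and compound 3 enter no step, and their results are limits of the assay, not numbers: the limit of > 10 uM in this assay, at which 2 of the 4 values shown sit.

For the compounds shown here, with only two chain lengths in hand, the course of the read-out between methylamino and pentylamino remains open, as does whether a longer chain such as hexylamino would lower the number further. Also open, going by these compounds, is what a plain amine in place of the alkylamino group would give on the same core.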